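The source may hold more compounds than are shown below. What is called first, only, known or untested is meant among the compounds shown, and "the series" means these compounds.

Values so far in a functional assay on HCT-116 cells (Homo sapiens) for cytotoxicity, read by MTT assay, with a stated time of 48 h; on this read-out higher numbers stand for weaker inhibition of growth and lower numbers for stronger inhibition of growth:
- compound 1 `CCn1c(C(F)(F)F)nc2cc(Cl)c(Cl)cc21` gives 95300 nM
- compound 2 `CCc1nc2cc(Cl)c(Cl)cc2n1C1CCCC1` gives 38000 nM
- compound 3 `FC(F)(F)c1nc2cc(Cl)c(Cl)cc2n1C1CCCC1` gives 22000 nM
- compound 4 `C[S+]([O-])c1nc2cc(Cl)c(Cl)cc2n1C1CCCC1` is not yet measured

Within the data shown here, compound 3 is separated from only one of its two neighbours. Its nearest gap is a 1.7-fold lower number from compound 2 to compound 3 (0.24 log units; within the scatter) and its furthest is a 4.3-fold lower number from compound 1 to compound 3 (0.64 log units; beyond the scatter), so it sits level with one compound and clear of the other.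

The next change is a group of 3 heavy atoms (1 carbon, 1 oxygen, 1 sulfur; no ring) in place of a group of 4 heavy atoms (1 carbon, 3 fluorine; no ring), on an aromatic carbon. Trifluoromethyl leaves the aromatic carbon between two ring nitrogen atoms, next to the ring atom that bears a cyclopentyl group, while the cyclopentyl group itself stays.

Among the measured compounds shown here, only one measured step touches this carbon: a 1.7-fold lower number from compound 2 to compound 3 (0.24 log units; within the scatter) for trifluoromethyl in place of ethyl. The other step, a 4.3-fold lower number from compound 1 to compound 3 (0.64 log units; beyond the scatter) for cyclopentyl in place of ethyl on an aromatic nitrogen, is modest and lies elsewhere on the molecule, so it bears little on this change. For the measured compounds named here, no measured compound carries the entering group, which leaves the direction open and the range wide.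

In this assay no step beyond the scatter is expected, and the estimated step is a 1.3-fold higher number from compound 3 to compound 4 (0.10 log units; within the scatter) on the middle value. The estimate for compound 4 is 28000 nM with an expected range from 10000 nM to 75000 nM in this read-out.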

Compound 4, concentration for 50% growth inhibition: 500 nM
Beside the measured number, compound 4's estimate is 56-fold (1.75 log units) above it; the measured number lies below the stated range.
By their numbers in this assay, from the lowest: compound 4; then compounds 3 and 2 (each within the scatter of the next); then compound 1.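

In this assay, among these compounds, the aromatic carbon between two ring nitrogen atoms proves far more responsive than the earlier compounds suggested: trifluoromethyl and ethyl there stay within the scatter of each other, whereas the group of 3 heavy atoms (1 carbon, 1 oxygen, 1 sulfur) gives a 44-fold lower number from compound 3 to compound 4 (1.64 log units; beyond the scatter) and a 76-fold lower number from compound 2 to compound 4 (1.88 log units; beyond the scatter) on the same carbon. Both new steps are large, and they exceed the modest 4.3-fold lower number from compound 1 to compound 3 (0.64 log units; beyond the scatter) for cyclopentyl in place of ethyl on the aromatic nitrogen, so within these compounds this carbon, not the nitrogen, carries the largest change in growth inhibition. Nothing available accounts for the separation of the entering group from trifluoromethyl and ethyl.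

Still open, as far as these compounds go, is whether the gain belongs to the sulfur, to the oxygen or to the group as a whole, a question that a methyl thioether, a methyl sulfone or an amine on this carbon would help to separate. Also open, from the compounds shown here alone, is whether the entering group keeps this effect with ethyl in place of cyclopentyl on the aromatic nitrogen.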